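The compounds below may be only part of what the source reports. "The series", "measured", "known", "first", "only" and "open" are said of these compounds alone.

Measured so far:
Compound 1, `CNC(=O)N1CCCc2ccc(NC(=O)c3cccc(-c4cnn(C)c4)c3)cc21`, gives 93.5% in a functional assay on MV4-11 cells (Homo sapiens) for antiproliferative activity, with a stated time of 6 days, tested at 6.25 uM; on this read-out higher numbers stand for a stronger effect at the one concentration tested and lower numbers for a weaker effect.
Compound 2, `CNC(=O)N1CCCc2ccc(NC(=O)c3cccc(-c4cc[nH]n4)c3)cc21`, gives 89.7%.
Compound 3, `CNC(=O)N1CCCc2ccc(NC(=O)c3cccc(-c4cnn(C(C)=O)c4)c3)cc21`, gives 82%.

Compound 3 shows the lowest of the three numbers: the step of a number 7.7 percentage points lower from compound 2 to compound 3 (within the scatter) stays within the scatter, while the step of a number 11.5 percentage points lower from compound 1 to compound 3 (beyond the scatter) lies beyond it. Compound 4, `CNC(=O)N1CCCc2ccc(NC(=O)c3cccc(-c4ccn(C(C)=O)n4)c3)cc21`, keeps every atom of compound 3 but joins them differently: 1-acetyl-1H-pyrazol-3-yl in place of 1-acetyl-1H-pyrazol-4-yl on an aromatic carbon. The closest guide is the step of a number 3.8 percentage points lower from compound 1 to compound 2 (within the scatter), where the point of attachment of the pyrazole ring also changed, and which stayed within the scatter. On that basis the step of a number 2 percentage points lower from compound 3 to compound 4 (within the scatter) is expected to be small, with no clear direction beyond the scatter. Compound 4 is therefore estimated at 80%, with a range from 67% to 91%.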

Compound 4, a percentage reported as inhibition, at one concentration (the size of the read-out at that concentration, not a potency): 87.6%
The estimate for compound 4 lay 7.6 percentage points below the measured number; the measured number falls inside the stated range.
By their numbers in this assay, from the lowest: compounds 3, 4, 2 and 1 (each within the scatter of the next, the first and the last beyond it).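

The swap of 1-acetyl-1H-pyrazol-4-yl for 1-acetyl-1H-pyrazol-3-yl gives a number 5.6 percentage points higher from compound 3 to compound 4 (within the scatter) and so cannot be told apart from repeat-measurement noise. Adding acetyl to the ring nitrogen of the 1H-pyrazol-3-yl group gives a number 2.1 percentage points lower from compound 2 to compound 4 (within the scatter) and also shows no clear effect. Replacing 1-methyl-1H-pyrazol-4-yl with 1-acetyl-1H-pyrazol-3-yl gives a number 5.9 percentage points lower from compound 1 to compound 4 (within the scatter), so this position tolerates the new group about as well as the earlier two.

Still open, from the compounds shown here alone, is how the position would respond to an amine or a carboxylic acid on the pyrazole, or to a longer chain in place of acetyl. Nothing measured here explains the size of these steps.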